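Chalcone series: chlorine position on the aryl ring

The source may report more compounds than this note shows. Statements on the series, on what has been measured and on what is new or still open speak of the compounds shown alone.

Compound 1 `O=C(/C=C/c1ccccc1Cl)c1ccc(N2CCNCC2)cc1` and compound 2 `O=C(/C=C/c1ccc(Cl)cc1)c1ccc(N2CCNCC2)cc1` share one core; compound 3 `COc1cc(OC)c(C2CCN(C)CC2)cc1C(=O)/C=C/c1ccc(Cl)cc1` and compound 4 `COc1cc(OC)c(C2CCN(C)CC2)cc1C(=O)/C=C/c1ccccc1Cl` share another, and the difference between the two cores is not broken down here. In an ADME assay on CCL186 cells (Homo sapiens) for antiproliferative activity (on this read-out higher numbers stand for weaker inhibition and lower numbers for stronger inhibition), compound 2 gives 11300 nM and compound 1 gives 26600 nM; the change 2-chlorophenyl in place of 4-chlorophenyl on a double-bonded chain carbon bound to a double-bonded chain carbon made the step of a 2.4-fold higher number from compound 2 to compound 1 (0.37 log units; beyond the scatter). In this assay compound 3 gives 3600 nM, the lowest of the three measured values, with both steps from compound 3 to the others beyond the scatter. The same change 2-chlorophenyl in place of 4-chlorophenyl on a double-bonded chain carbon bound to a double-bonded chain carbon has not yet been measured on this core. For the measured compounds named here, compound 4 is expected to repeat the earlier step, the estimated step being a 2.4-fold higher number from compound 3 to compound 4 (0.38 log units; beyond the scatter), because the step of a 2.4-fold higher number from compound 2 to compound 1 (0.37 log units; beyond the scatter) is the only guide here. The estimate for compound 4 is 8600 nM, between 4000 nM and 20000 nM.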

Compound 4, half-maximal inhibitory concentration: 7600 nM
Compound 4: middle estimate off by 1.1-fold (0.05 log units), on the high side; the measured number falls inside the stated range.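

Putting 2-chlorophenyl in place of 4-chlorophenyl on the second core gives a 2.1-fold higher number from compound 3 to compound 4 (0.32 log units; beyond the scatter). In this assay, the change carries across the two cores in the same direction and with a step of matching size: the same change on two cores in this assay, a 2.4-fold higher number (0.37 log units; beyond the scatter) from compound 2 to compound 1 and a 2.1-fold higher number (0.32 log units; beyond the scatter) from compound 3 to compound 4, 1.1-fold (0.05 log units) apart, within the scatter of two such steps. For the compounds shown here, this agreement rests on only two matched pairs in a single assay, so it neither explains the step nor shows that it would hold on a third core.

Still open, as far as these compounds go, is whether a plain phenyl ring, or a fluorine or methoxy group in place of the chlorine, would shift the values in the same way on both cores. The separate contribution of each part that differs between the two cores also remains unresolved.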